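The compounds below may be only part of what the source reports. "The series", "measured", "known", "first", "only" and "open" are said of these compounds alone.

Compound 1, with structure `CCOC(=O)c1cnc(N2CCN(Cc3ccc(C(=O)OC)cc3)CC2)nc1Oc1c(C)cc(-c2ccc(C#N)cc2)cc1C`, sits at the edge of what an ADME assay on MT4 cells (Homo sapiens) for cytotoxicity, read by MTT assay, with a stated time of 4 days (a lower number here means that less compound is tolerated, a higher number that more compound is tolerated), can report: in this assay compound 1 gives > 125000 nM, which is a limit of the assay and not a measured number. For the measured compounds named here, its only measured neighbour, compound 2 (`CCOC(=O)c1cnc(N2CCN(Cc3cccc(Br)c3)CC2)nc1Oc1c(C)cc(-c2ccc(C#N)cc2)cc1C`), differs from it by a 3-bromophenyl in place of the 4-(methoxycarbonyl)phenyl on a saturated chain carbon bound to an amine nitrogen in a ring. In this assay compound 2 gives > 125000 nM, again a limit. The step that the two limits leave unreadable from compound 1 to compound 2 therefore cannot be sized; what the data offer is the limit of > 125000 nM in this assay, at which 2 of the 2 values shown sit. Compound 3 (`CCOC(=O)c1cnc(N2CCN(Cc3ccc(S(C)(=O)=O)cc3)CC2)nc1Oc1c(C)cc(-c2ccc(C#N)cc2)cc1C`) has not yet been measured. It carries methylsulfonyl in place of methoxycarbonyl on an aromatic carbon, so that the 4-(methoxycarbonyl)benzyl of compound 1 becomes a 4-(methylsulfonyl)benzyl. Going by the values given here, no measured step bears directly on this exchange, and the one step available is unreadable, so no shift beyond the scatter is expected in this assay; the step that the limit leaves unreadable from compound 1 to compound 3 is what is anticipated. Compound 3 is estimated to give 150000 nM in this assay, expected to fall between 80000 nM and 300000 nM, and most likely to be reported once more as a limit.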

Compound 3, half-maximal cytotoxic concentration: > 125000 nM
Compound 3: no number, only a limit; the forecaster's own chance of this, stated with the estimate: 75%; the middle value lies beyond the limit too.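

In this assay compound 3 gives > 125000 nM, which is a limit of the assay and not a number. No step among compound 1, compound 2 and compound 3 can be read: the limit of > 125000 nM in this assay, at which 3 of the 3 values shown sit.

The compounds shown leave open how much compound is tolerated past that limit, and whether any exchange on the benzyl group changes it.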